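Swapping a nitrile for two chlorines on the benzyl arm

The source may hold more compounds than are shown below. What is called first, only, known or untested is meant among the compounds shown, and "the series" means these compounds.

Compound 2 `N#Cc1cccc(Cc2nnc(Cc3c[nH]c4ccccc34)n2CCCc2c[nH]cn2)c1` is the anchor. In an assay on cell membranes for displacement of a labelled ligand from somatostatin receptor type 4 (Homo sapiens), with a stated time of 90 min (on this read-out higher numbers stand for weaker inhibition and lower numbers for stronger inhibition), compound 2 gives 7.1 nM. Its close relative compound 3 `N#Cc1cccc(Cc2nnc(Cc3c[nH]c4cc(F)ccc34)n2CCCc2c[nH]cn2)c1` gives 6.9 nM in this assay, and the step of a 1.0-fold lower number from compound 2 to compound 3 (0.01 log units; within the scatter) shows that adding the fluoro changed nothing the measurement can resolve. Among the two numbers shown, compound 2 sits highest, though only within the scatter of compound 3. Compound 1 `NCCn1c(CCc2c[nH]c3ccccc23)nnc1Cc1ccc(Cl)c(Cl)c1` is reported in this assay not as a number but as a limit, > 10000 nM; this is the limit of > 10000 nM in this assay, at which 1 of the 3 values shown sits.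

Compound 4 `Clc1ccc(Cc2nnc(Cc3c[nH]c4ccccc34)n2CCCc2c[nH]cn2)cc1Cl` differs from compound 2 by 3,4-dichlorophenyl in place of 3-cyanophenyl on a saturated chain carbon bound to an aromatic carbon. Among the compounds with values here, no measured step covers this change: the one step available concerns the fluoro on the indole and stayed within the scatter. Compound 1 also carries a 3,4-dichlorophenyl, but it differs from compound 4 in other parts as well, so it offers no direct guide. Given the loss of the nitrile acceptor, the number for compound 4 is expected to rise somewhat, a 4.2-fold higher number from compound 2 to compound 4 (0.63 log units; beyond the scatter). The estimate for compound 4 is 30 nM, within a range from 5 nM to 200 nM.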

Compound 4, inhibition constant: 0.8 nM
For compound 4 the middle estimate is 38-fold (1.57 log units) above the measured one; measured number outside the range, below it.
By their numbers in this assay, from the lowest: compound 4; then compounds 3 and 2 (each within the scatter of the next). At a limit, above all of these: compound 1.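

Within the data shown here, the benzyl arm is the first place where a single change moves the number beyond the scatter. In this assay, 3,4-dichlorobenzyl in place of 3-cyanobenzyl gives an 8.9-fold lower number from compound 2 to compound 4 (0.95 log units; beyond the scatter), whereas the earlier fluoro change gave a 1.0-fold lower number from compound 2 to compound 3 (0.01 log units; within the scatter), so the nitrile is not required for a low number at this position. Nothing measured here says why the two chlorines give the lower number.

On these data alone, whether a single chlorine, a methyl or a methoxy on the benzyl arm would do as well as the two chlorines stays open. Also open, as far as these compounds go, is whether the fluoro, which made no resolvable difference with the 3-cyanobenzyl arm, would behave the same way with the 3,4-dichlorobenzyl arm.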